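A bromo group on a compound at the assay limit

A few compounds are considered here, and "the series" means these few. Any claim that something is new, unique, unknown or untested is made for them only; others in the source may bear on it.

Measured so far:
compound 1 `S=C(N/N=C/c1cccs1)Nc1ccccc1`: > 100000 nM
compound 2 `C=CCNC(=S)N/N=C/c1cccs1`: > 100000 nM

In a functional assay on NCI-H460 cells (Homo sapiens) for inhibition, read by sulforhodamine B assay, with a stated time of 48 h (on this read-out lower numbers stand for stronger inhibition of growth and higher numbers for weaker inhibition of growth), compound 1 gives > 100000 nM, which is a limit of the assay and not a number. Compound 2 gives > 100000 nM, which is also a limit. Compound 1 therefore stands at the limit of > 100000 nM in this assay, at which 2 of the 2 values shown sit, and no exact value is known for it.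

Compound 3 `S=C(N/N=C/c1cccs1)Nc1ccc(Br)cc1` keeps the core of compound 1 and changes in one place: bromo in place of hydrogen on an aromatic carbon. This puts bromo in place of hydrogen on an aromatic carbon, para to a large group. Among the compounds with values here, no measured pair shows what such a change does here, so any forecast is uncertain, and compound 3 may also end up at a limit. The expected change is an at least 1.6-fold lower number from compound 1 to compound 3 (0.22 log units; that floor lies within the scatter), a modest move toward stronger inhibition of growth. Compound 3 is estimated at 60000 nM, with an expected range from 15000 nM to 100000 nM.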

Compound 3, concentration for 50% growth inhibition: 4700 nM
For compound 3 the middle estimate is 13-fold (1.11 log units) above the measured one; measured number outside the range, below it.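

In this assay, putting bromo in place of hydrogen on the six-membered aromatic ring, para to a large group, gives an at least 21-fold lower number from compound 1 to compound 3 (1.32 log units; beyond the scatter). Compound 1 gives > 100000 nM, which is a limit of the assay and not a number. Compound 3 is therefore the only compound shown with an exact value, and this one-atom change is the only one shown that brings growth inhibition into the range the assay can put a number on: the limit of > 100000 nM in this assay, at which 2 of the 3 values shown sit.

On these data alone, what stays open is whether this effect belongs to bromo in particular or would also appear with another group at the same place, such as chloro, methoxy or an amine. As far as these compounds go, it is also open whether bromo elsewhere on the same ring would give a similar result.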